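A few compounds are considered here, and "the series" means these few. Any claim that something is new, unique, unknown or untested is made for them only; others in the source may bear on it.

Working notes on the series. Three compounds have numbers in a functional assay on CHO cells for agonist activity at Alpha-2B adrenergic receptor (Homo sapiens); a lower number here means that less compound is needed, a higher number that more compound is needed for the effect. Compound 1 `Cc1cccc(C)c1OC(C)C1=NCCN1` gives 1480 nM. Compound 2 `CCc1ccccc1OC(C)C1=NCCN1` gives 10000 nM. Compound 3 `C=CCc1cccc(CC=C)c1OC(C)C1=NCCN1` gives 501 nM. Compound 2 stands at the highest number of the three; its nearest neighbour is compound 1, whose number is lower by a margin beyond the scatter, and the furthest is compound 3, lower by a wider margin, also beyond the scatter. Going by the values given here, no pair among the three differs in one place only, so no single step between measured compounds can be taken from these numbers.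

The step under consideration leads from compound 2 to compound 4 `CCOc1ccccc1OC(C)C1=NCCN1`, not yet measured in this assay. The change is ethoxy in place of ethyl on an aromatic carbon. None of the measured compounds carries an ethoxy, so the shown values give no direct guide for this exchange, only the observation that the ethyl-bearing compound 2 sits at the top of the range. The expected step is a 2.0-fold lower number from compound 2 to compound 4 (0.30 log units; within the scatter), a small move toward a lower number, with a result inside the scatter of compound 2 equally plausible. For compound 4 the estimate in this assay is 5000 nM, with a range from 1500 nM to 20000 nM, and a real chance that only a limit is reported.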

Compound 4, half-maximal effective concentration: 3160 nM
Estimate against measurement, compound 4: 1.6-fold (0.20 log units) above; the measured number falls inside the stated range.
By their numbers in this assay, from the lowest: compound 3; then compound 1; then compound 4; then compound 2.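

Ethoxy in place of ethyl on an aromatic carbon gives a 3.2-fold lower number from compound 2 to compound 4 (0.50 log units; beyond the scatter) in this assay, the first single-place step in the series and the first direct reading of this position. The change replaces a group of two carbons with one that holds the same two carbons plus an oxygen, counted as one hydrogen-bond acceptor, and that exchange alone moves the number beyond the scatter. No measurement offered here bears on why the number moves, and the step remains an observation without an explanation.

The step does not separate the oxygen from the added chain length, so a propyl group, with the same count of heavy atoms but no oxygen, and a methoxy group, with the oxygen on a shorter chain, would be the telling neighbours at this place. Compounds 1 and 3 differ from compound 4 in more than one place, so it also stays open whether ethoxy would have the same effect alongside a second group on the aromatic ring, and an amine or a hydroxy group at this place remains unexplored in the compounds shown.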